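Series notes: fused-ring lactam aryl amides, antiproliferative read-out

The source may hold more compounds than are shown below. What is called first, only, known or untested is meant among the compounds shown, and "the series" means these compounds.

Measured compounds:
compound 1, `COc1cccc(N2C(=O)COc3ccc(-c4cnc5ccccc5c4)cc32)c1`, > 40000 nM
compound 2, `O=C1COc2ccc(-c3cnc(Cl)c(NS(=O)(=O)c4ccc(F)cc4)c3)cc2N1`, > 40000 nM
compound 3, `O=C1COc2ccc(-c3cccc(NS(=O)(=O)c4ccc(F)cc4)c3)cc2N1c1ccc(Cl)cc1`, 39800 nM

Within the data shown here, in a functional assay on MCF7 cells (Homo sapiens) for antiproliferative activity, read by MTT assay, with a stated time of 72 h (a higher number here means a weaker inhibitor, a lower number a stronger inhibitor), compound 3 gives 39800 nM, the only value in the set reported as a number. For compound 1 the result is a limit, > 40000 nM, and not a number. For compound 2 the result is likewise a limit, > 40000 nM. Compound 3 therefore stands at the edge of what this assay reports, with the limit of > 40000 nM in this assay, at which 2 of the 3 values shown sit, describing where the other two values sit. Among the measured compounds shown here, no step between two measured compounds that differ in one place is available, so no measured effect of any single change can be read off.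

Compound 4, `COc1cccc(N2C(=O)COc3ccc(-c4cccc(NS(=O)(=O)c5ccc(F)cc5)c4)cc32)c1`, is not yet measured. It differs from compound 3 as follows: 3-methoxyphenyl in place of 4-chlorophenyl on an amide-type nitrogen in a ring. The step from compound 3 to compound 4 is expected to be small, within the scatter or at most a drift towards weaker inhibition, as a 1.1-fold higher number from compound 3 to compound 4 (0.05 log units; within the scatter), given that compound 3 sits at 39800 nM already. Compound 4 is estimated at 45000 nM, between 20000 nM and 100000 nM, with a substantial chance that this assay reports only a limit.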

Compound 4, half-maximal inhibitory concentration: > 40000 nM
Compound 4 ended at the assay's limit; the forecaster's own chance of this, stated with the estimate: 65%; the middle value is on the limit's open side.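

In this assay compound 4 gives > 40000 nM, which is a limit of the assay and not a number. Among these compounds, this is the only step that differs in one place, on an amide-type nitrogen in a ring, and the exchange of 4-chlorophenyl for 3-methoxyphenyl reads as a number no lower from compound 3 to compound 4 (the limit leaves the size open); the direction is bounded, but the size cannot be read. At this position, then, 3-methoxyphenyl brings no gain over 4-chlorophenyl, and compound 3 remains the only compound with a number, while the rest of the set lies at one edge of the read-out: the limit of > 40000 nM in this assay, at which 3 of the 4 values shown sit.

Open, as far as these compounds go, is whether a group of another kind on this nitrogen, such as a carboxylic acid or a chain ending in an amine, would move the read-out in this assay clear of the limit. Also open is how much the sulfonamide shared by compound 3 and compound 4 contributes, as no step shown touches that part of the structure.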